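A pyrazole carboxamide: anilino traded for ethylamino

A few compounds are considered here, and "the series" means these few. Any claim that something is new, unique, unknown or untested is made for them only; others in the source may bear on it.

Compound 1 `CCOc1ccc(NC(=O)c2c(N)n[nH]c2Nc2ccccc2)cc1` is assessed in a functional assay on Huh-7 cells (Homo sapiens) for cytotoxicity, read by resazurin assay, with a stated time of 48 h (a higher number here means a weaker inhibitor, a lower number a stronger inhibitor), where compound 1 gives 4320 nM, the lowest of the two numbers in hand. The only other measured entry is compound 2 `CCOc1ccc(NC(=O)CC#N)cc1`, which in this assay gives 21500 nM; the two structures differ in more than one place, so only their two values can be compared, and the gap between them lies beyond the usual scatter.

Compound 3 `CCNc1[nH]nc(N)c1C(=O)Nc1ccc(OCC)cc1` is not yet measured. Against compound 1 it shows ethyl in place of phenyl on a nitrogen on an aromatic ring: the anilino becomes ethylamino. Going by the values given here, no measured pair shows this change, so nothing in the data fixes its size. The expectation for the step of a 1.9-fold higher number from compound 1 to compound 3 (0.27 log units; within the scatter) is a modest rise in the number, at the edge of the scatter or somewhat beyond it. Compound 3 is therefore estimated at 8000 nM, with a range from 2500 nM to 25000 nM.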

Compound 3, half-maximal inhibitory concentration: 27000 nM
For compound 3 the middle estimate is 3.4-fold (0.53 log units) below the measured one; measured number above the stated range.
By their numbers in this assay, from the lowest: compound 1; then compounds 2 and 3 (each within the scatter of the next).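

Going by these compounds alone, this is the first comparison that isolates a single change: with the rest of compound 1 held constant, ethyl in place of phenyl on a nitrogen on an aromatic ring gives a 6.3-fold higher number from compound 1 to compound 3 (0.80 log units; beyond the scatter) in this assay. At this position, therefore, the phenyl group cannot be exchanged for ethyl without a shift larger than the usual scatter, and the lower number belongs to the compound that carries the aromatic ring. Nothing available explains why the number moves with this change.

This single step cannot separate the loss of the aromatic ring from the loss of carbon, since phenyl brings both and ethyl neither to the same degree. As far as these compounds go, how a cyclohexyl group, a benzyl group or a longer chain such as hexyl would behave on that nitrogen remains open, as does the effect of a bare amine there.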